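The source may hold more compounds than are shown below. What is called first, only, known or untested is meant among the compounds shown, and "the series" means these compounds.

Measured so far:
compound 1 `O=C(N/N=C/c1ccc(F)cc1)Nc1cc2c(Nc3ccc(F)c(Cl)c3)ncnc2cc1O[C@H]1CCOC1` gives "not active" (no number reported) in a functional assay on PC-3 cells (Homo sapiens) for cytotoxicity, read by MTT assay, with a stated time of 72 h; on this read-out lower numbers stand for stronger inhibition and higher numbers for weaker inhibition
compound 2 `COc1cc(/C=N/NC(=O)Nc2cc3c(Nc4ccc(F)c(Cl)c4)ncnc3cc2O[C@H]2CCOC2)cc(OC)c1OC` gives 29600 nM in this assay
compound 3 `COc1cc2ncnc(Nc3ccc(F)c(Cl)c3)c2cc1NC(=O)N/N=C/c1ccc(F)cc1` gives 36500 nM in this assay

Within the data shown here, compound 3 carries the highest of the two numbers so far, but its nearest neighbour, compound 2, sits only a little lower, and that gap is within the scatter of repeated measurements, so the two cannot be told apart. Compound 1 returned no number at all in this assay. All three share the same core, and the measured numbers cluster at the weak end of the range.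

Compound 4 `CCN(CC)c1ccc(/C=N/NC(=O)Nc2cc3c(Nc4ccc(F)c(Cl)c4)ncnc3cc2OC)c(O)c1` differs from compound 3 in one place: 4-(diethylamino)-2-hydroxyphenyl in place of 4-fluorophenyl on a carbon with a double bond to nitrogen. Among the measured compounds shown here, no measured pair shows this change, so its effect is unknown here. The expectation for compound 4 is a step from compound 3 of about a 1.5-fold lower number from compound 3 to compound 4 (0.16 log units; within the scatter), that is, no change clearly beyond the scatter, because compound 2 gives 29600 nM and compound 3 gives 36500 nM, numbers that differ little despite different groups at the same position. Compound 4 is estimated at 25000 nM, within a range of 6000 nM to 90000 nM.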

Compound 4, half-maximal inhibitory concentration: 34300 nM
For compound 4 the middle estimate is 1.4-fold (0.14 log units) below the measured one; the range from low to high includes it.
By their numbers in this assay, from the lowest: compounds 2, 4 and 3 (each within the scatter of the next).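

In this assay, among these compounds, the one-place change from 4-fluorophenyl to 4-(diethylamino)-2-hydroxyphenyl on a carbon with a double bond to nitrogen gives the first readable step at this position (a 1.1-fold lower number from compound 3 to compound 4 (0.03 log units; within the scatter)). The entering group has more heavy atoms, and it has a hydrogen-bond donor and acceptors where the leaving group has none, yet this assay does not separate the two compounds. No measurement here explains that outcome.

From the compounds shown here alone, both groups in this step are six-membered aromatic rings of carbon only, so it remains open whether a saturated ring such as cyclohexyl, or a phenyl ring carrying a carboxylic acid, would shift the number. Going by these compounds, it also remains open whether the same change would give a similar result on the core of compound 1.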